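Aryl swap on the anilino nitrogen: compounds 3 and 4

The source may hold more compounds than are shown below. What is called first, only, known or untested is meant among the compounds shown, and "the series" means these compounds.

Of the compounds shown here, three of this urea series have been measured in a functional assay on PC-9 cells (Homo sapiens) for inhibition, read by MTT assay, with a stated time of 48 h, tested at 10 uM; a lower number here means less inhibition, a higher number more inhibition at the concentration tested (going by the name of the read-out). Compound 1 `CCc1ccc(Nc2cc(NC(=O)Nc3cc(OC)cc(OC)c3)ncn2)cc1` gives 78%. Compound 2 `COc1cc(NC(=O)Nc2cc(Nc3ccc(F)c(Cl)c3)ncn2)cc(OC)c1` gives 77.5%. Compound 3 `O=C(Nc1cc(Nc2ccc(F)c(Cl)c2)ncn1)Nc1c(Cl)cccc1Cl` gives 91.1%, the highest of the three, and its gap to both compound 1 and compound 2 lies beyond the scatter. Compound 2 and compound 3 share the anilino group but differ in the urea-bearing part; that difference between the two cores is not broken down here.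

Compound 4 `CCc1ccc(Nc2cc(NC(=O)Nc3c(Cl)cccc3Cl)ncn2)cc1` has not yet been measured in this assay. It differs from compound 3 by 4-ethylphenyl in place of 3-chloro-4-fluorophenyl on a nitrogen on an aromatic ring. The same change, (4-ethylphenyl in place of 3-chloro-4-fluorophenyl on a nitrogen on an aromatic ring), is already covered by the measured pair, where it made a number 0.5 percentage points higher from compound 2 to compound 1 (within the scatter). Both changes sit at a place described in the same words, so they count as the same change.

On the strength of that measured pair, the step from compound 3 to compound 4 is expected to be about a number 1.1 percentage points lower from compound 3 to compound 4 (within the scatter), which rests on a number 0.5 percentage points higher from compound 2 to compound 1 (within the scatter) having stayed within the scatter. Compound 4 is therefore estimated at 90%, in the range 80% to 97%.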

Compound 4, a percentage reported as inhibition, at one concentration (the size of the read-out at that concentration, not a potency): 70.1%
For compound 4 the middle estimate is 19.9 percentage points above the measured one; measured number below the stated range.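

Putting 4-ethylphenyl in place of 3-chloro-4-fluorophenyl on the nitrogen gives, in this assay, a number 21 percentage points lower from compound 3 to compound 4 (beyond the scatter). The change therefore does not carry over from one core to the other at a constant size: the same change on two cores in this assay, a number 0.5 percentage points higher (within the scatter) from compound 2 to compound 1 and a number 21 percentage points lower (beyond the scatter) from compound 3 to compound 4, 21.5 percentage points apart, beyond the scatter of two such steps

These two pairs show that the outcome of this swap depends on the core that carries it, so a step read on one core is a poor guide to the other; they do not show which part of the urea-bearing side is responsible, or how the swap would behave on any further core.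

Among the compounds shown here, only two groups on the nitrogen appear here, so it remains open whether the lower number for compound 4 follows from gaining the ethyl group or from losing the chlorine and fluorine. A plain phenyl, or a propyl chain in place of the ethyl, on the core of compound 3 would help to separate these two readings.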